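Lengthening the amide chain: from methylamino to propylamino

The compounds below may be only part of what the source reports. "The series", "measured", "known", "first", "only" and "open" are said of these compounds alone.

Compound 1 `O=C(C1CC1)[C@H]1C[C@@H]2CNC[C@@H](C2)C1`: 7100 nM
Compound 2 `O=C(c1ccco1)[C@H]1C[C@@H]2CNC[C@@H](C2)C1`: "not determined" (no result reported)
Compound 3 `CNC(=O)[C@H]1C[C@@H]2CNC[C@@H](C2)C1`: 2000 nM

Among the measured compounds shown here, in an assay on SHEP1 cells for agonist activity at Neuronal acetylcholine receptor; alpha4/beta2 (Homo sapiens), read by FLIPR and calcium flux (a higher number here means that more compound is needed for the effect, a lower number that less compound is needed), compound 3 gives the lowest of the two numbers available; the single measured step is a 3.6-fold lower number from compound 1 to compound 3 (0.55 log units; beyond the scatter), and it lies beyond the scatter. Compound 4 `CCCNC(=O)[C@H]1C[C@@H]2CNC[C@@H](C2)C1` differs from compound 3 by ethyl in place of hydrogen on a saturated chain carbon bound to an amide-type nitrogen. For the measured compounds named here, no measured step alters the chain on the amide nitrogen; the one step known exchanges the whole group on the carbonyl carbon, so it offers no direct guide to this change. Without a comparable step, the move from compound 3 to compound 4 is expected to stay within the scatter, a 1.3-fold higher number from compound 3 to compound 4 (0.10 log units; within the scatter). For compound 4 the estimate is 2500 nM, with a range from 700 nM to 9000 nM.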

Compound 4, half-maximal effective concentration: 2400 nM
The estimate for compound 4 lay 1.0-fold (0.02 log units) above the measured number; low and high end bracket the measured number.
By their numbers in this assay, from the lowest: compounds 3 and 4 (each within the scatter of the next); then compound 1.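

Among the compounds shown here, this is the first measured change to the chain on the amide nitrogen: methylamino and propylamino show a 1.2-fold higher number from compound 3 to compound 4 (0.08 log units; within the scatter) in this assay and cannot be told apart, so ethyl in place of hydrogen at this place leaves no measurable mark. Propylamino on the carbonyl carbon also gives a 3.0-fold lower number from compound 1 to compound 4 (0.47 log units; beyond the scatter) in this assay and so stays clear of cyclopropyl there. No available evidence bears on this result. From the compounds shown here alone, whether a longer chain such as hexyl, or a chain ending in an amine or a carboxylic acid, would fit the same pattern remains open.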